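Cytotoxicity notes: sulfonyl chain to difluoro-hydroxy chain

This account rests on a few compounds, and the source may have more. Where it says the series, first, only, none or still open, it means among the compounds named here.

In an ADME assay on HEp-2 cells (Homo sapiens) for cytotoxicity, with a stated time of 4 days (a lower number here means that less compound is tolerated, a higher number that more compound is tolerated), compound 1 `CS(=O)(=O)CCCn1c(Cn2nc(S(C)(=O)=O)c3ccccc32)nc2cc(Cl)ccc21` gives > 100000 nM, which is a limit of the assay and not a number. In this assay compound 3 `CC(C)S(=O)(=O)c1cn(Cc2nc3cc(Cl)ccc3n2CCCS(C)(=O)=O)c2ccccc12` gives > 100000 nM, again a limit. Compound 2 `CS(=O)(=O)CCCn1c(Cn2nc(S(C)(=O)=O)c3ccncc32)nc2cc(Cl)ccc21` stands at > 100000 nM in this assay, also a limit rather than a measured number. All values shown thus sit at the same limit, as recorded in the limit of > 100000 nM in this assay, at which 3 of the 3 values shown sit; on these numbers compound 2 cannot be placed above or below compound 1 or compound 3.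

Compound 4 `CS(=O)(=O)c1nn(Cc2nc3cc(Cl)ccc3n2CCC(O)C(F)F)c2cnccc12` differs from compound 2 by 2,2-difluoro-1-hydroxyethyl in place of (methylsulfonyl)methyl on a saturated chain carbon, two bonds along the chain from an aromatic nitrogen.

Going by the values given here, no step between two measured compounds is available in this assay, so the size of the change cannot be read from the series; no step beyond the scatter is expected, in either direction. Compound 4 is expected to give about 150000 nM in this assay, with a range from 50000 nM to 500000 nM. The expected step is a step that the limit leaves unreadable from compound 2 to compound 4, which is estimated to stay within the scatter, and a limit rather than a number is the most likely outcome.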

Compound 4, half-maximal cytotoxic concentration: > 100000 nM
Compound 4: only a limit was reported (the forecaster's own chance of this, stated with the estimate: 80%); the middle value lies beyond the limit too.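

Compound 4 gives > 100000 nM in this assay, again a limit and not a number. No step can be read from compound 2 to compound 4 because both values are limits: the limit of > 100000 nM in this assay, at which 4 of the 4 values shown sit.

The compounds shown leave open where any half-maximal cytotoxic concentration in this series actually lies, and whether 2,2-difluoro-1-hydroxyethyl in place of (methylsulfonyl)methyl shifts it at all.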